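Swapping tert-butyl for isobutyl on compound 1

This account rests on a few compounds, and the source may have more. Where it says the series, first, only, none or still open, it means among the compounds named here.

Compound 1 `CC(C)(C)/N=C(\S)NCCCCn1nc(-c2ccccc2)ccc1=O` — > 100 mg/kg
Compound 2 `CC/N=C(\S)NCCCn1nc(-c2ccccc2)ccc1=O` — > 100 mg/kg
Compound 3 `C/N=C(/NC#N)NCCCCCn1nc(-c2ccccc2)cc(C)c1=O` — > 100 mg/kg

The three measured compounds were tested in a functional assay on the whole organism (stomach) with Rattus norvegicus as the target; on this read-out higher numbers stand for an effect only at larger amounts of compound and lower numbers for an effect already at smaller amounts. Compound 1 gives only a limit of the assay there, > 100 mg/kg, not a number. Compound 2 likewise returns a limit, > 100 mg/kg. Compound 3 also sits at a limit, > 100 mg/kg. Compound 1 therefore stands where every other measured compound stands: at the limit of > 100 mg/kg in this assay, at which 3 of the 3 values shown sit, with no number that would place it higher or lower than its companions.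

The new compound 4 `CC(C)C/N=C(\S)NCCCCn1nc(-c2ccccc2)ccc1=O` is built from compound 1 by a single change: isobutyl in place of tert-butyl on a double-bonded nitrogen. The leaving and entering groups carry the same atoms joined differently, and the rest of the molecule, including the shared core, is untouched.

Within the data shown here, no pair of measured compounds differs in only one place, so no measured step guides this change. Given that all three measured compounds rest at a limit, the step from compound 1 to compound 4 in this assay is expected to be none beyond the usual scatter, and the most likely outcome is another limit. Compound 4 is therefore estimated at 100 mg/kg, within 30 mg/kg to 300 mg/kg, which amounts to an expected step of a number no higher from compound 1 to compound 4 (the limit leaves the size open).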

Compound 4, dose for half-maximal effect: > 100 mg/kg
Compound 4: a limit, no number; the forecaster's own chance of this, stated with the estimate: 80%; the middle value lies on the limit itself.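

In this assay, compound 1 and compound 4 both give only a limit and not a number, so no step can be read between them: the limit of > 100 mg/kg in this assay, at which 4 of the 4 values shown sit.

The compounds shown leave open whether isobutyl and tert-butyl on the double-bonded nitrogen differ at all in this assay, and at what dose any of these compounds would produce a half-maximal effect.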